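The source may hold more compounds than are shown below. What is called first, only, known or untested is meant among the compounds shown, and "the series" means these compounds.

Measured so far in an assay on HEK293 cells for agonist activity at Toll-like receptor 8 (Homo sapiens), read by spectrophotometry; on this read-out higher numbers stand for an effect only at larger amounts of compound and lower numbers for an effect already at smaller amounts:

- compound 1 `CCCCNc1nc(N)nc(C)c1CCCN1CCCCCC1`: 178 nM
- compound 2 `CCCCNc1nc(N)nc(C)c1C`: 3280 nM
- compound 3 `CCCCNc1nc(N)nc(C)c1C#CCN1CCCCC1`: 3790 nM

Compound 2 holds the second highest of the three numbers in this assay. Its nearest neighbour is compound 3, whose number lies within the scatter of it, so no order between the two is claimed. Compound 1 stands far below both, beyond the scatter.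

Compound 4 `CCCCNc1nc(N)nc(C)c1CC` is not yet measured. It differs from compound 2 by methyl in place of hydrogen on a saturated chain carbon bound to an aromatic carbon. Among the compounds with values here, no step of this kind has been measured, so the expectation rests on the small size of the change. The step of a 1.3-fold lower number from compound 2 to compound 4 (0.12 log units; within the scatter) is expected to be small, if anything a slight lowering, and may well stay within the scatter. Compound 4 is therefore expected to give about 2500 nM, within 900 nM to 7000 nM.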

Compound 4, half-maximal effective concentration: 1660 nM
Estimate against measurement, compound 4: 1.5-fold (0.18 log units) above; the range from low to high includes it.
By their numbers in this assay, from the lowest: compound 1; then compounds 4, 2 and 3 (each within the scatter of the next, the first and the last beyond it).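

In this assay, within the data shown here, methyl in place of hydrogen on a saturated chain carbon bound to an aromatic carbon gives a 2.0-fold lower number from compound 2 to compound 4 (0.30 log units; within the scatter) as the first step that differs in one place. At this position, methyl to ethyl therefore leaves the two compounds within the scatter of each other. Nothing measured here speaks to the reason for this result.

From the compounds shown here alone, whether a propyl chain or a longer chain at this position would move the number beyond the scatter remains open. So does the effect of a hydroxyl group on the ethyl chain.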